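Working notes: replacing trifluoromethyl with methyl in the series

The source may hold more compounds than are shown below. What is called first, only, known or untested is meant among the compounds shown, and "the series" means these compounds.

Measured so far in an ADME assay on BHK-21 cells (Mesocricetus auratus) for cytotoxicity, read by MTT assay, with a stated time of 72 h; on this read-out lower numbers stand for higher toxicity in this test and higher numbers for lower toxicity in this test:
- compound 1 `Cc1ccc(NCc2cn(-c3ccccc3)nc2-c2ccc(Cl)cc2)cc1` gives > 100000 nM, a limit of the assay and not a number
- compound 2 `Cc1ccc(NCc2cn(-c3ccccc3)nc2-c2ccc(C(F)(F)F)cc2)cc1` gives 88000 nM

Among the compounds with values here, compound 2 carries the only actual number so far. Compound 1 stands at the limit of > 100000 nM in this assay, at which 1 of the 2 values shown sits, so its reading is a limit only.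

Compound 3 `Cc1ccc(NCc2cn(-c3ccccc3)nc2-c2ccc(C)cc2)cc1` is still to be measured. It differs from compound 2 by methyl in place of trifluoromethyl on an aromatic carbon, para to a large group: methyl in place of trifluoromethyl on an aromatic carbon.

Within the data shown here, one measured step bears on this change, at the same kind of carbon: an at least 1.1-fold lower number from compound 1 to compound 2 (0.05 log units; that floor lies within the scatter). That step, with trifluoromethyl in place of chloro, gives only a floor, and the floor does not leave the scatter. On that evidence from compound 2, no step beyond the scatter is expected in this assay, and no direction can be favoured. The expected change is a 1.1-fold higher number from compound 2 to compound 3 (0.03 log units; within the scatter), which would stay within the scatter. For compound 3 the estimated value is 95000 nM, with an expected range from 55000 nM to 160000 nM.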

Compound 3, half-maximal cytotoxic concentration: > 100000 nM
Compound 3 ended at the assay's limit; the forecaster's own chance of this, stated with the estimate: 50%; middle value at least 1.0-fold (0.02 log units) from the limit.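

In this assay, methyl in place of trifluoromethyl on this aromatic carbon, para to a large group, gives an at least 1.1-fold higher number from compound 2 to compound 3 (0.05 log units; that floor lies within the scatter), so a second change at this position yields only a floor that stays within the scatter. Compound 3 gives > 100000 nM, a limit of the assay and not a number. The step between compound 1 and compound 3 cannot be read, and compound 2 still carries the only actual number, so the readings at this position now rest largely on one limit: the limit of > 100000 nM in this assay, at which 2 of the 3 values shown sit.

The compounds shown leave open whether any group at this position would move the number beyond the scatter, for instance an amine or a carboxylic acid in place of methyl. They also leave open how far past the limit compound 1 and compound 3 actually lie, so no order among the chloro, methyl and trifluoromethyl compounds can be drawn from these readings.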